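This account rests on a few compounds, and the source may have more. Where it says the series, first, only, none or still open, it means among the compounds named here.

Measured compounds in an assay on HEK293 cells for inhibition of Steryl-sulfatase (Homo sapiens), tested at 1 uM; on this read-out lower numbers stand for a weaker effect and higher numbers for a stronger effect at the one concentration tested:
compound 1 `CCN(Cc1ccccc1)c1cccc(C(=O)N2CCc3ccc(OS(N)(=O)=O)cc3C2)c1`: 69%
compound 2 `CN(CCCN1CCCCC1)c1cccc(C(=O)N2CCc3ccc(OS(N)(=O)=O)cc3C2)c1`: 30.6%

Going by the values given here, compound 2 stands lowest of the two numbers in this assay; its nearest neighbour is compound 1, with 69%, and the only measured step, a number 38.4 percentage points lower from compound 1 to compound 2 (beyond the scatter), runs downward and beyond the scatter. The next compound, compound 3 `CN(C)CCN(CCN(C)C)c1cccc(C(=O)N2CCc3ccc(OS(N)(=O)=O)cc3C2)c1`, is not yet measured. It differs from compound 2 at one place: bis(2-(dimethylamino)ethyl)amino in place of methyl(3-(piperidin-1-yl)propyl)amino on an aromatic carbon.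

Among the compounds with values here, the single step on record bears on this change only loosely: it replaced a benzyl(ethyl)amino group with an amine-bearing chain and cost a number 38.4 percentage points lower from compound 1 to compound 2 (beyond the scatter). Compound 3 keeps an amine-bearing chain in that position and, like compound 2, carries no benzyl group, so no return toward compound 1 is expected. The expected step is a number 4.6 percentage points lower from compound 2 to compound 3 (within the scatter), within the scatter, with a wide range. Compound 3 is therefore estimated at 26%, between 5% and 50%.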

Compound 3, a percentage reported as inhibition, at one concentration (the size of the read-out at that concentration, not a potency): 17.1%
The estimate for compound 3 lay 8.9 percentage points above the measured number; the measured number falls inside the stated range.
By their numbers in this assay, from the lowest: compound 3; then compound 2; then compound 1.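

In this assay the exchange of methyl(3-(piperidin-1-yl)propyl)amino for bis(2-(dimethylamino)ethyl)amino on the aromatic carbon gives a number 13.5 percentage points lower from compound 2 to compound 3 (beyond the scatter) even though both groups have the same heavy-atom count. The number at this position therefore differs between two groups without a benzyl group, one with a six-membered non-aromatic ring and one with no ring and an additional nitrogen. Measured against benzyl(ethyl)amino, the new group gives a number 51.9 percentage points lower from compound 1 to compound 3 (beyond the scatter) and compound 1 remains the highest of the three compounds. No measurement on record accounts for these steps.

The compounds shown do not separate the loss of the piperidine ring from the gain of the additional nitrogen. A morpholine at the end of the propyl chain or a benzyl(methyl)amino group would test the next changes at this position.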